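This account rests on a few compounds, and the source may have more. Where it says the series, first, only, none or still open, it means among the compounds named here.

Compound 1 `COc1cc(O)c(C)c2c1CC[C@H](c1ccc(O)cc1)O2`: 35500 nM
Compound 2 `COc1cc2c(cc1O)C[C@@H](Cc1ccc(O)cc1)CO2`: 19100 nM

In a functional assay on A549 cells (Homo sapiens) for cytotoxicity, read by MTT assay, with a stated time of 72 h (a higher number here means a weaker inhibitor, a lower number a stronger inhibitor), compound 1 gives 35500 nM and compound 2 gives 19100 nM. These two numbers lie within the scatter of each other, so they cannot be ranked. Compound 3 `Cc1c(O)ccc2c1O[C@@H](c1ccc(O)cc1)CC2` differs from compound 1 at one place: hydrogen in place of methoxy on an aromatic carbon. Hydrogen stands in place of methoxy on an aromatic carbon, para to a methyl group. Going by the values given here, no measured pair shows this change alone, so the only anchor is compound 1 at 35500 nM, and no step beyond the scatter is expected in this assay. The estimated move is a 1.2-fold lower number from compound 1 to compound 3 (0.07 log units; within the scatter). For compound 3 the expected value is 30000 nM, with an estimated range of 12000 nM to 75000 nM.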

Compound 3, half-maximal inhibitory concentration: 39700 nM
For compound 3 the middle estimate is 1.3-fold (0.12 log units) below the measured one; measured number inside the range.
By their numbers in this assay, from the lowest: compounds 2, 1 and 3 (each within the scatter of the next, the first and the last beyond it).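

Putting hydrogen in place of the methoxy group on this aromatic carbon, para to a methyl group, gives a step in this assay (a 1.1-fold higher number from compound 1 to compound 3 (0.05 log units; within the scatter)). At this position, then, compound 1 and compound 3 cannot be told apart, and the methoxy group is not required for the activity seen with compound 1.

The compounds shown leave open whether other groups on this carbon, such as an amine, a carboxylic acid or a longer chain like butoxy, would stay within the scatter. Nothing available here explains the result.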